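This account rests on a few compounds, and the source may have more. Where it says the series, first, only, none or still open, it means among the compounds named here.

Three compounds have been measured in a functional assay on MIA PaCa-2 cells (Homo sapiens) for cytotoxicity, read by luminescence, with a stated time of 72 h; a higher number here means a weaker inhibitor, a lower number a stronger inhibitor:

compound 1 `CNC(=S)N/N=C/c1ncc(F)c2ccccc12`, 2080 nM
compound 2 `CN(C)C(=S)NN=Cc1ncc(F)c2ccccc12`, 274 nM
compound 3 `CNC(=S)NN=Cc1nccc2c(N)cccc12`, 11200 nM

Compound 2 stands at the lowest number of the three in this assay. Compound 1 gives a higher number, and the gap lies beyond the usual scatter; compound 3 gives a higher number still, again beyond the scatter. Within the data shown here, both compound 1 and compound 3 differ from compound 2 in more than one place, so none of the measured pairs isolates a single structural change.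

Compound 4 `CN(C)C(=S)NN=Cc1nccc2ccccc12` has not yet been measured. It differs from compound 2 in one place only:

hydrogen in place of fluoro on an aromatic carbon

Among the measured compounds shown here, no measured pair shows what this change does in this assay, so the expectation rests on judgment of the shared core rather than on a recorded step. The fluoro is a single heavy atom with no donor or acceptor; its loss is expected to move the number modestly upward, quite possibly staying within the scatter. The expected step is a 1.6-fold higher number from compound 2 to compound 4 (0.22 log units; within the scatter). Compound 4 is therefore estimated at 450 nM, with a range from 150 nM to 1500 nM.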

Compound 4, concentration for 90% inhibition: 29600 nM
The estimate for compound 4 lay 66-fold (1.82 log units) below the measured number, outside the stated range (above it).
By their numbers in this assay, from the lowest: compound 2; then compound 1; then compound 3; then compound 4.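

In this assay, the aromatic carbon two atoms from the ring nitrogen proves far from indifferent: hydrogen in place of fluoro gives a 110-fold higher number from compound 2 to compound 4 (2.03 log units; beyond the scatter), a large step for the loss of a single heavy atom with no hydrogen-bond donors or acceptors. Compound 1 and compound 3 each differ from compound 2 in more than one place, so neither could show how much this one position matters. No measurement at hand gives a reason for a step of this size.

As far as these compounds go, whether the number depends on fluoro specifically or on having any group at this carbon stays open; chloro, methyl or methoxy there would help separate the two. From the compounds shown here alone, whether hydrogen in place of fluoro has as large a step with the side chain of compound 1 also stays open.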